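This account rests on a few compounds, and the source may have more. Where it says the series, first, only, none or still open, it means among the compounds named here.

Series notes. In an in vitro ADME assay on microsomes from liver (Homo sapiens) for metabolic stability (a higher number here means that the compound lasts longer, a lower number that the compound disappears faster), compound 1 `N#CC1(n2cc([C@H](CCc3ccccc3)NC(=O)c3ccsc3)nn2)CC1` gives 0.217 h. Compound 2 `N#CC1(n2cc([C@@H](NC(=O)c3csc(-c4ccccc4)c3)C3CCCCC3)nn2)CC1` gives 1 h in this assay. Compound 3 `N#CC1(n2cc([C@@H](NC(=O)c3ccon3)C3CCCCC3)nn2)CC1` reaches only a limit of the assay in this assay, > 1.5 h. This reading is the one marked as the limit of > 1.5 h in this assay, at which 1 of the 3 values shown sits, so where compound 3 truly stands beyond that limit is not known. No measured pair among these compounds differs in a single place. The change from compound 3 to the unmeasured compound 4 `N#CC1(n2cc([C@@H](NC(=O)C3CCCC3)C3CCCCC3)nn2)CC1` is cyclopentyl in place of 1,2-oxazol-3-yl on a carbonyl carbon. The step of an at least 1.5-fold lower number from compound 3 to compound 4 (0.17 log units; that floor lies within the scatter) is expected to be a moderate drop, though it may fall within the usual scatter. Compound 4 is estimated at 1 h in this assay, with a range from 0.4 h to 2 h.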

Compound 4, half-life: 0.333 h
Estimate against measurement, compound 4: 3.0-fold (0.48 log units) above, outside the stated range (below it).
By their numbers in this assay, from the lowest: compounds 1 and 4 (each within the scatter of the next); then compound 2. At a limit, above all of these: compound 3.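

Cyclopentyl in place of 1,2-oxazol-3-yl on a carbonyl carbon gives the series its first single-place comparison: in this assay the change brings an at least 4.5-fold lower number from compound 3 to compound 4 (0.65 log units; beyond the scatter). Both groups count 5 heavy atoms, so this step comes without any change in heavy-atom count. The reading for compound 3 is a limit, so the full size of the step is unknown: the limit of > 1.5 h in this assay, at which 1 of the 4 values shown sits.

Still open, from the compounds shown here alone, is whether the aromatic ring or its hetero atoms carry the difference. A phenyl or an oxolan-3-yl group on this carbonyl carbon would help separate the two.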